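Replacing trifluoromethyl with bromo: how large a step?

This account rests on a few compounds, and the source may have more. Where it says the series, first, only, none or still open, it means among the compounds named here.

Compound 1 `N#Cc1ccc(NC(=O)c2cc(-c3ccccc3)ccc2O)cc1` gives 1300 nM
Compound 2 `N#Cc1ccc(NC(=O)c2cc(C(F)(F)F)ccc2O)cc1` gives 4810 nM

In a functional assay on KG-1 cells (Homo sapiens) for cytotoxicity, read by luminescence and CellTiter-Glo, with a stated time of 3 days (on this read-out higher numbers stand for weaker inhibition and lower numbers for stronger inhibition), compound 2 has the higher of the two numbers, which makes it the weaker inhibitor of the pair. Compound 3 `N#Cc1ccc(NC(=O)c2cc(Br)ccc2O)cc1` has not yet been measured. Its change from compound 2 bromo in place of trifluoromethyl on an aromatic carbon puts bromo in place of trifluoromethyl on an aromatic carbon, para to a hydroxy group. Within the data shown here, only one measured step bears on this: a 3.7-fold higher number from compound 1 to compound 2 (0.57 log units; beyond the scatter) when trifluoromethyl replaced phenyl on that carbon. That step was modest, though beyond the scatter. Among the measured compounds shown here, no measured compound carries bromo, so only a small move towards a lower number is expected in this assay and probably none beyond the scatter. The estimated step is a 1.4-fold lower number from compound 2 to compound 3 (0.14 log units; within the scatter) on this reasoning. For compound 3 the estimated value is 3500 nM with 1300 nM to 9000 nM as the expected range.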

Compound 3, half-maximal inhibitory concentration: 1290 nM
Compound 3: the middle estimate sits 2.7-fold (0.43 log units) above what was measured, outside the stated range (below it).
By their numbers in this assay, from the lowest: compounds 3 and 1 (each within the scatter of the next); then compound 2.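

With bromo on this carbon, this assay shows a 3.7-fold lower number from compound 2 to compound 3 (0.57 log units; beyond the scatter), so the higher number seen so far belongs to trifluoromethyl alone among these three groups. Bromo, which has no ring, and phenyl, which is a ring, give results within the usual scatter of each other, with a 1.0-fold lower number from compound 1 to compound 3 (0.00 log units; within the scatter), so carrying a ring on this carbon does not separate these two compounds. No measurement here explains why trifluoromethyl stands apart from the other two groups.

On these data alone, three groups are too few to show a trend at this carbon, and whether a chloro group, a methoxy group or an amine would fall with bromo and phenyl or with trifluoromethyl remains open. As far as these compounds go, these compounds also vary only this one carbon, so what the hydroxy group or the nitrile contributes stays unknown.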